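The compounds below may be only part of what the source reports. "The series", "measured", "known", "first", "only" and "open" are said of these compounds alone.

In a functional assay on MCF7 cells (Homo sapiens) for cytotoxicity, read by MTT assay, with a stated time of 72 h (a lower number here means a stronger inhibitor, a higher number a weaker inhibitor), compound 1 `COc1ccc2[nH]c(-c3ccc[nH]3)c(C3CC(=O)NC3=O)c2c1` gives 19000 nM and compound 3 `O=C1CC(c2c(-c3ccc[nH]3)[nH]c3ccccc23)C(=O)N1` gives 35000 nM. Going by the values given here, these are the only two true numbers so far. Among the compounds with values here, the one measured step, hydrogen in place of methoxy on an aromatic carbon, is a 1.8-fold higher number from compound 1 to compound 3 (0.27 log units; within the scatter), so the two compounds cannot be told apart. Compound 4 `COc1ccc2[nH]c(-c3ccc[nH]3)cc2c1` has not yet been measured and differs from compound 1 in one place: hydrogen in place of 2,5-dioxopyrrolidin-3-yl on an aromatic carbon. Within the data shown here, no measured step removes the 2,5-dioxopyrrolidin-3-yl group, so the methoxy step offers little guidance here. Compound 2 `c1ccc2[nH]c(-n3cccn3)cc2c1` also lacks that group, though it differs from compound 4 elsewhere too. Compound 2 gives > 100000 nM, which is a limit and not a number. Among the measured compounds shown here, with compound 2 at that limit of > 100000 nM as the only guide, a move towards a higher number, meaning a weaker inhibitor, is expected, though with wide uncertainty. The estimated change is a 2.6-fold higher number from compound 1 to compound 4 (0.42 log units; beyond the scatter). In this assay, the estimate for compound 4 is 50000 nM, with an expected range from 15000 nM to 150000 nM.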

Compound 4, half-maximal inhibitory concentration: 84000 nM
For compound 4 the middle estimate is 1.7-fold (0.23 log units) below the measured one, within the range that was stated.
By their numbers in this assay, from the lowest: compounds 1 and 3 (each within the scatter of the next); then compound 4. At a limit, above all of these: compound 2.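

Going by these compounds alone, this is the first measured change at the aromatic carbon that carries the 2,5-dioxopyrrolidin-3-yl group in compound 1, and in this assay replacing that group with hydrogen gives a 4.4-fold higher number from compound 1 to compound 4 (0.65 log units; beyond the scatter). Unlike the methoxy change, a 1.8-fold higher number from compound 1 to compound 3 (0.27 log units; within the scatter), this modest step lies beyond the scatter, so the 2,5-dioxopyrrolidin-3-yl group counts for something measurable at this position. Even so, compound 4 still gives a true number, 84000 nM, so a measurable effect on the cells remains without the group.

Still open, as far as these compounds go, is which part of the 2,5-dioxopyrrolidin-3-yl group matters, and how an amine or a carboxylic acid on the same carbon would compare. Within the data shown here, compound 2 differs in more than one place and its value is a limit, not a number, so no step to it can be read: the limit of > 100000 nM in this assay, at which 1 of the 4 values shown sits.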